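This account rests on a few compounds, and the source may have more. Where it says the series, first, only, none or still open, it means among the compounds named here.

In a functional assay on HCT-116 cells (Homo sapiens) for cytotoxicity, read by MTT assay, with a stated time of 72 h (on this read-out higher numbers stand for weaker inhibition and lower numbers for stronger inhibition), compound 1 `Cc1cc(/C=C/c2ccc(O)c(O)c2)on1` gives 5300 nM and compound 2 `COc1ccc(/C=C/c2cc(C)no2)cc1` gives 22400 nM. Compound 2 therefore holds the higher of the two numbers, and its gap to compound 1 lies beyond the scatter. Among the measured compounds shown here, these two compounds do not differ in one place only, so their values offer no single-change step. Compound 3 `Cc1cc(/C=C/c2ccc(O)cc2)on1` differs from compound 2 by hydrogen in place of methyl on an oxygen on an aromatic ring, or methoxy to hydroxy. Compound 1, which also carries no methoxy, stands at 5300 nM, so a moderate move toward lower numbers is expected in this assay, beyond the scatter but uncertain in size. The estimated step is a 2.0-fold lower number from compound 2 to compound 3 (0.31 log units; beyond the scatter). The expected value for compound 3 is 11000 nM, with an estimated range of 4500 nM to 26000 nM.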

Compound 3, half-maximal inhibitory concentration: 67900 nM
Estimate against measurement, compound 3: 6.2-fold (0.79 log units) below; measured number outside the range, above it.
By their numbers in this assay, from the lowest: compound 1; then compound 2; then compound 3.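

In this assay, methoxy to hydroxy on the aromatic ring does not bring a lower number: this change gives a 3.0-fold higher number from compound 2 to compound 3 (0.48 log units; beyond the scatter) and so runs against the direction that compound 1 had suggested. The extra hydroxy of compound 1 carries far more weight, since hydrogen in place of hydroxy on an aromatic carbon gives a 13-fold higher number from compound 1 to compound 3 (1.11 log units; beyond the scatter) in a large step, so the low number of compound 1 cannot be credited to the absence of methoxy alone. Nothing given here accounts for either step.

The compounds shown leave open whether an ethyl or longer chain in place of methyl on the oxygen would keep the number of compound 2 or shift it. They also leave open where an amine or a carboxylic acid in place of the extra hydroxy of compound 1 would fall relative to compound 1 and compound 3.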